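This account rests on a few compounds, and the source may have more. Where it says the series, first, only, none or still open, it means among the compounds named here.

Compound 3 `O=C(c1cccc(C(F)(F)F)c1)N(/N=N/c1ccc([N+](=O)[O-])cc1C(F)(F)F)c1ccc([N+](=O)[O-])cc1C(F)(F)F` gives the lowest number of the three measured in a functional assay on HeLa cells (Homo sapiens) for cytotoxicity, read by MTT assay, with a stated time of 72 h (a lower number here means a stronger inhibitor, a higher number a weaker inhibitor), at 750 nM. Compound 1 `O=[N+]([O-])c1ccc(/N=N/Nc2ccc([N+](=O)[O-])cc2Cl)c(Cl)c1` stands nearest with 3010 nM, and compound 2 `O=C(c1ccccc1C(F)(F)F)N(/N=N/c1ccc([N+](=O)[O-])cc1C(F)(F)F)c1ccc([N+](=O)[O-])cc1C(F)(F)F` furthest with 5350 nM. Within the data shown here, the one single-point step recorded, a 7.1-fold lower number from compound 2 to compound 3 (0.85 log units; beyond the scatter), shows that moving the trifluoromethyl on the aryl of the carbonyl group already shifts the number beyond the scatter. Compound 4 `O=C(CCl)N(/N=N/c1ccc([N+](=O)[O-])cc1C(F)(F)F)c1ccc([N+](=O)[O-])cc1C(F)(F)F` differs from compound 3 by chloromethyl in place of 3-(trifluoromethyl)phenyl on a carbonyl carbon. Among the measured compounds shown here, no measured step covers a change of this kind; the acyl group is altered far more than between compound 2 and compound 3, so a step beyond the scatter is expected, most likely toward a higher number, as a 2.1-fold higher number from compound 3 to compound 4 (0.33 log units; beyond the scatter). Compound 4 is therefore estimated at 1600 nM, within 400 nM to 6500 nM.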

Compound 4, half-maximal inhibitory concentration: 800 nM
Estimate against measurement, compound 4: 2.0-fold (0.30 log units) above; the range from low to high includes it.
By their numbers in this assay, from the lowest: compounds 3 and 4 (each within the scatter of the next); then compounds 1 and 2 (each within the scatter of the next).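

In this assay the position on the carbonyl carbon accepts a large exchange, with a 1.1-fold higher number from compound 3 to compound 4 (0.03 log units; within the scatter) even though 3-(trifluoromethyl)phenyl has 10 heavy atoms and chloromethyl has 2. An aromatic ring on this carbonyl is thus not needed to reach the level of compound 3, and a 6.7-fold lower number from compound 2 to compound 4 (0.83 log units; beyond the scatter) leaves 2-(trifluoromethyl)phenyl as the outlier among these acyl groups. No available evidence explains either step. Whether the chlorine matters remains open, since the compounds shown include no plain methyl on this carbonyl. A longer alkyl chain or an aminomethyl group there also remains untested in the compounds shown.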